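The source may report more compounds than this note shows. Statements on the series, on what has been measured and on what is new or still open speak of the compounds shown alone.

In a functional assay on OVCAR-3 cells (Homo sapiens) for antiproliferative activity, read by MTT assay, with a stated time of 24 h (on this read-out higher numbers stand for weaker inhibition and lower numbers for stronger inhibition), compound 1 `O=c1[nH]cc(S(=O)(=O)Nc2ccccc2-c2cn(-c3ccc(F)cc3)nn2)c(=O)[nH]1` gives > 20000 nM, which is a limit of the assay and not a number. Compound 2 `O=c1[nH]cc(S(=O)(=O)Nc2cccc(-c3cn(-c4ccccc4)nn3)c2)c(=O)[nH]1` gives > 20000 nM, also a limit, so its position on the scale is known only as a limit. For the measured compounds named here, the series so far comes down to this: the limit of > 20000 nM in this assay, at which 2 of the 2 values shown sit. Compound 3 `O=c1[nH]cc(S(=O)(=O)Nc2cccc(-c3cn(-c4ccccc4F)nn3)c2)c(=O)[nH]1` differs from compound 2 by fluoro in place of hydrogen on an aromatic carbon, or phenyl to 2-fluorophenyl. Going by the values given here, no measured step is available to size such a change in this assay. The estimated step of a number no higher from compound 2 to compound 3 (the limit leaves the size open) is expected to stay within the scatter, with no direction favoured, and another limit is the likely report. Compound 3 is estimated at 20000 nM, with an expected range of 10000 nM to 40000 nM.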

Compound 3, half-maximal inhibitory concentration: 12500 nM
Beside the measured number, compound 3's estimate is 1.6-fold (0.20 log units) above it, and the stated range covers the measured number.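

In this assay, for the compounds shown here, fluoro on an aromatic carbon, ortho to a large group, gives the first value that is a number and not a limit. Going by these compounds, the change gives an at least 1.6-fold lower number from compound 2 to compound 3 (0.20 log units; that floor lies within the scatter), so it can be sized from one side only: its true size stays open, and a shift within the scatter is not excluded. Every other compound shown remains at the limit: the limit of > 20000 nM in this assay, at which 2 of the 3 values shown sit.

The compounds shown leave open whether chloro, methoxy or an amine in this same place would give a number in this assay, and how such a number would compare with that of compound 3. With a single number in the series, no trend across substituents can be drawn yet.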